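From cyclopentyl to cyclobutylmethyl: a clearance question

A few compounds are considered here, and "the series" means these few. Any claim that something is new, unique, unknown or untested is made for them only; others in the source may bear on it.

Compound 1 `COc1cc2c(Nc3cnc(OCCCC4CCCC4)nc3)ncnc2cc1OCCCN1CCCCC1`: 96 mL.min-1.g-1
Compound 2 `CNc1nc(OC2CCCC2)nc2c1ncn2Cc1c(F)cccc1F`: 240 mL.min-1.g-1
Compound 3 `CNC(=O)c1sc(N2CC3CC2(CNC(=O)c2c[nH]c4ncc(C(F)(F)F)cc24)C3)nc1C(F)(F)F`: 130 mL.min-1.g-1

In an ADME assay on microsomes from liver (Homo sapiens) for metabolic stability (on this read-out lower numbers stand for slow clearance and higher numbers for fast clearance), compound 2 gives 240 mL.min-1.g-1. That value lies within the scatter of compound 3 and beyond the scatter above compound 1.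

Compound 4 `CNc1nc(OCC2CCC2)nc2c1ncn2Cc1c(F)cccc1F` has not been measured. It has the same atoms as compound 2, joined differently, with cyclobutylmethyl in place of cyclopentyl on an oxygen on an aromatic ring.

Among the measured compounds shown here, no measured pair shows a change of this kind, so compound 2 is the only guide. The expected 1.1-fold lower number from compound 2 to compound 4 (0.04 log units; within the scatter) is no shift beyond the scatter. For compound 4 the estimate is 220 mL.min-1.g-1, with an expected range from 120 mL.min-1.g-1 to 400 mL.min-1.g-1.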

Compound 4, intrinsic clearance in microsomes in the Homo sapiens assay: > 270 mL.min-1.g-1
Compound 4: a limit, no number; the forecaster's own chance of this, stated with the estimate: 5%; at least 1.2-fold (0.08 log units) between middle value and limit.
By their numbers in the Homo sapiens assay, from the lowest: compounds 1, 3 and 2 (each within the scatter of the next, the first and the last beyond it). At a limit, above all of these: compound 4.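

Among the compounds shown here, this is the first reading of cyclobutylmethyl in place of cyclopentyl on an oxygen on an aromatic ring, and in the Homo sapiens assay it shows an at least 1.1-fold higher number from compound 2 to compound 4 (0.05 log units; that floor lies within the scatter). In the Homo sapiens assay compound 4 gives > 270 mL.min-1.g-1, which is a limit and not a number. In a physicochemical assay for solubility (on this read-out lower numbers stand for lower solubility and higher numbers for higher solubility), compound 2 gives 9000 nM and compound 4 gives 4000 nM. In the physicochemical assay the same change also lowers solubility: the measured solubility of compound 2, 9000 nM, and of compound 4, 4000 nM, a 2.3-fold lower number (0.35 log units; beyond the scatter)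

Going by these compounds, how far the clearance of compound 4 lies past that limit stays open, so the full size of the step is unknown. Also open, on these data alone, is what a carboxylic acid in place of cyclopentyl would do to either read-out.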